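Amide in place of sulfonamide: compound 3 to compound 4

This account rests on a few compounds, and the source may have more. Where it says the series, first, only, none or still open, it means among the compounds named here.

Measured in a functional assay on MV4-11 cells (Homo sapiens) for cytotoxicity, read by MTT assay, with a stated time of 72 h; a lower number here means a stronger inhibitor, a higher number a weaker inhibitor:
compound 1 `CCOC(=O)c1csc2nc(-c3ccc(NC(=O)CC)cc3)cn12` gives 9520 nM
compound 2 `CCOC(=O)c1csc2nc(-c3ccc(NC(=O)Nc4ccc(Br)cn4)cc3)cn12` gives 2440 nM
compound 3 `CCOC(=O)c1csc2nc(-c3ccc(NS(=O)(=O)c4ccc(C)cc4)cc3)cn12` reaches only the assay limit, > 20000 nM

Compound 3 stands at the limit (the limit of > 20000 nM in this assay, at which 1 of the 3 values shown sits); its value is a limit, not a number. Compound 4 `CCOC(=O)c1csc2nc(-c3ccc(NC(=O)c4ccco4)cc3)cn12` differs from compound 3 by (furan-2-yl)carbonyl in place of (4-methylphenyl)sulfonyl on a nitrogen on an aromatic ring. For the measured compounds named here, the steps that bear on this are the two in which the sulfonyl entered: an at least 2.1-fold higher number from compound 1 to compound 3 (0.32 log units; beyond the scatter) and an at least 8.1-fold higher number from compound 2 to compound 3 (0.91 log units; beyond the scatter). Compound 4 reverses that change, returning to an amide on the aromatic nitrogen, and both amide-type compounds 1 and 2 sit below the limit. A drop beyond the scatter is therefore expected, an at least 2.5-fold lower number from compound 3 to compound 4 (0.39 log units; beyond the scatter), placing compound 4 near compound 1. Compound 4 is estimated at 8000 nM, between 3000 nM and 20000 nM.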

Compound 4, half-maximal inhibitory concentration: 9920 nM
For compound 4 the middle estimate is 1.2-fold (0.09 log units) below the measured one, within the range that was stated.
By their numbers in this assay, from the lowest: compound 2; then compounds 1 and 4 (each within the scatter of the next). At a limit, above all of these: compound 3.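

In this assay, compound 3 carries a limit, not a number: the limit of > 20000 nM in this assay, at which 1 of the 4 values shown sits.

Replacing the sulfonyl with the furan-2-yl amide gives an at least 2.0-fold lower number from compound 3 to compound 4 (0.30 log units; that floor lies within the scatter), so the size of this change stays unread. On the carbonyl carbon, furan-2-yl and ethyl are indistinguishable, a 1.0-fold higher number from compound 1 to compound 4 (0.02 log units; within the scatter), whereas losing (5-bromopyridin-2-yl)amino gives a 4.1-fold higher number from compound 2 to compound 4 (0.61 log units; beyond the scatter).

Open, going by these compounds, is whether the lower number of compound 2 rests on the bromopyridine ring or on its amino link. A phenyl ring directly on that carbonyl carbon, or a plain amine there, would separate the two.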